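Hydrazone aryl variation at the imine carbon

A few compounds are considered here, and "the series" means these few. Any claim that something is new, unique, unknown or untested is made for them only; others in the source may bear on it.

Two members of the series have been measured in an assay on isolated protein for inhibition of Maltase-glucoamylase (Homo sapiens), with a stated time of 15 min; on this read-out higher numbers stand for weaker inhibition and lower numbers for stronger inhibition. Compound 1 `O=C(N/N=C/c1ccc(O)cc1)c1ccc(-c2nc3ccccc3s2)cc1` gives 11300 nM, and compound 2 `O=C(N/N=C/c1cccs1)c1ccc(-c2nc3ccccc3s2)cc1` gives 8480 nM. The step of a 1.3-fold lower number from compound 1 to compound 2 (0.12 log units; within the scatter) shows that exchanging the aryl on the carbon with a double bond to nitrogen left the read-out unchanged within the scatter. Going by the values given here, on the numbers so far compound 2 carries the lower of the two values, but it cannot be separated from compound 1.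

Compound 3 `O=C(N/N=C/c1ccccc1O)c1ccc(-c2nc3ccccc3s2)cc1` is the next variation at the same position: 2-hydroxyphenyl in place of thiophen-2-yl on a carbon with a double bond to nitrogen. Among the compounds with values here, the only measured step that bears on this change is the aryl exchange from compound 1 to compound 2, which was within the scatter, so nothing beyond the scatter is expected for the exchange to 2-hydroxyphenyl either. No step beyond the scatter in either direction is expected; the estimated step of a 1.1-fold higher number from compound 2 to compound 3 (0.05 log units; within the scatter) reflects this. Compound 3 is therefore estimated at 9500 nM in this assay, with a range from 4000 nM to 22000 nM.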

Compound 3, half-maximal inhibitory concentration: 5550 nM
For compound 3 the middle estimate is 1.7-fold (0.23 log units) above the measured one, within the range that was stated.
By their numbers in this assay, from the lowest: compounds 3, 2 and 1 (each within the scatter of the next, the first and the last beyond it).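

In this assay, going by these compounds alone, the step of a 2.0-fold lower number from compound 1 to compound 3 (0.31 log units; beyond the scatter) is the first at the carbon with a double bond to nitrogen to lie beyond the scatter, so 2-hydroxyphenyl and 4-hydroxyphenyl can now be told apart, though the separation is modest. The step of a 1.5-fold lower number from compound 2 to compound 3 (0.18 log units; within the scatter) stays within the scatter, so 2-hydroxyphenyl and thiophen-2-yl cannot be separated, even though the exchange replaces a five-membered ring containing sulfur with a six-membered carbon ring and adds a hydrogen-bond donor. The three aryl groups therefore cover only a narrow span, with compound 2 within the scatter of both compound 1 and compound 3, and only the two hydroxyphenyl groups differ measurably.

From the compounds shown here alone, it remains open whether a carboxylic acid or a dimethylamino group on the aryl ring, or a longer alkyl chain in its place, would shift the read-out further than these aryl exchanges. Going by these compounds, all three compounds also share the same core, so the effect of a change elsewhere in the molecule on this assay is unknown.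

No available evidence accounts for the difference between the two hydroxyphenyl compounds.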